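The source may report more compounds than this note shows. Statements on the series, on what has been measured and on what is new or still open speak of the compounds shown alone.

Compound 1 `Cc1cc(CN(CC2CC2)C(CC(=O)O)c2ccc(Cl)cc2)ccc1OCCn1c(=O)ccn(C)c1=O` and compound 2 `COc1cc(CN(CC2CC2)C(CC(=O)O)c2ccc(Cl)cc2)ccc1OCCn1c(=O)ccn(C)c1=O` share one core. In a physicochemical assay for solubility, at pH 1.1 (a lower number here means a less soluble compound, a higher number a more soluble compound), compound 1 gives 3000000 nM and compound 2 gives 3000000 nM. The step of no change at the digits printed from compound 2 to compound 1 (within the scatter) comes from methyl in place of methoxy on an aromatic carbon. Compound 3 `COc1cc(CN(CC(C)C)C(CC(=O)O)c2ccc(Cl)c(F)c2)ccc1OCCN1C(=O)CCC1=O` carries a second core; the difference between the two cores is not broken down here. In this assay compound 3 gives 3000000 nM, level with compounds 1 and 2. Compound 4 `Cc1cc(CN(CC(C)C)C(CC(=O)O)c2ccc(Cl)c(F)c2)ccc1OCCN1C(=O)CCC1=O` is not yet measured and differs from compound 3 by methyl in place of methoxy on an aromatic carbon, the same kind of change as before, but here the place is ortho to a 2-(2,5-dioxopyrrolidin-1-yl)ethoxy group rather than ortho to a large group. In this assay the expected step for compound 4 is no change at the digits printed from compound 3 to compound 4 (within the scatter), resting on no change at the digits printed from compound 2 to compound 1 (within the scatter). Compound 4 is therefore estimated at 3000000 nM, expected between 1500000 nM and 6000000 nM.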

Compound 4, solubility: 3000000 nM
Compound 4: middle estimate and measured number agree at the digits printed; the range from low to high includes it.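

In this assay the swap of methoxy for methyl gives the same outcome on both cores: no change at the digits printed from compound 2 to compound 1 (within the scatter) on the first, and no change at the digits printed from compound 3 to compound 4 (within the scatter) on the second, where the place is ortho to a 2-(2,5-dioxopyrrolidin-1-yl)ethoxy group. This shows agreement across these two pairs only, and it does not show that the change would carry to any other core or read-out. Nothing measured here bears on the reason for this result. Open, as far as these compounds go, is how an amine or a trifluoromethyl group at this aromatic carbon would read in this assay on either core. Also open, from the compounds shown here alone, is whether a longer chain in place of the methoxy would leave the step unchanged.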